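The compounds below may be only part of what the source reports. "The series", "measured", "known", "first", "only" and "open" are said of these compounds alone.

Measured compounds:
compound 1, `CN(C)c1ccc(C2CC(c3ccc(-n4cncn4)cc3)=NN2C(=O)c2ccc(C(F)(F)F)cc2)cc1`, with 11.5%
compound 2, `CN(C)c1ccc(C2CC(c3ccc(-n4cncn4)cc3)=NN2S(C)(=O)=O)cc1`, with -3.1%
compound 3, `CN(C)c1ccc(C2CC(c3ccc(-n4ccnc4)cc3)=NN2C(=O)c2ccc(C(F)(F)F)cc2)cc1`, with 15.9%

All three were tested in a functional assay on NCI-H1975 cells (Homo sapiens) for inhibition, read by sulforhodamine B assay, tested at 10 uM; a lower number here means less inhibition, a higher number more inhibition at the concentration tested (going by the name of the read-out). Compound 2 differs from compound 1 in one place: methylsulfonyl in place of (4-(trifluoromethyl)phenyl)carbonyl on an amine nitrogen in a ring. This exchange made a step of a number 14.6 percentage points lower from compound 1 to compound 2 (beyond the scatter). Compound 3 differs from compound 1 at another point, in the group on the phenyl ring: 1H-imidazol-1-yl in place of 1H-1,2,4-triazol-1-yl on an aromatic carbon; the step here, a number 4.4 percentage points higher from compound 1 to compound 3 (within the scatter), lies within the scatter, so the two cores are not distinguished by this assay.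

Compound 4, `CN(C)c1ccc(C2CC(c3ccc(-n4ccnc4)cc3)=NN2S(C)(=O)=O)cc1`, has not yet been measured in this assay. It stands to compound 3 as compound 2 stands to compound 1: methylsulfonyl in place of (4-(trifluoromethyl)phenyl)carbonyl on an amine nitrogen in a ring. The surroundings of the place are not identical, since in compound 1 the ring atom two ring bonds away bears a 4-(1H-1,2,4-triazol-1-yl)phenyl group, whereas in compound 3 it bears a 4-(1H-imidazol-1-yl)phenyl group; the change is therefore the same kind of change, not the same change. Because the first instance gave a number 14.6 percentage points lower from compound 1 to compound 2 (beyond the scatter) and the two cores differ only by a number 4.4 percentage points higher from compound 1 to compound 3 (within the scatter), a step of about the same size is expected from compound 3 to compound 4, namely a number 14.4 percentage points lower from compound 3 to compound 4 (beyond the scatter). On this basis compound 4 is estimated at 1.5% in this assay, with the likely range running from -11% to 14%.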

Compound 4, a percentage reported as inhibition, at one concentration (the size of the read-out at that concentration, not a potency): -3.8%
Compound 4: the middle estimate sits 5.3 percentage points above what was measured; the measured number falls inside the stated range.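

In this assay, methylsulfonyl in place of (4-(trifluoromethyl)phenyl)carbonyl gave a number 19.7 percentage points lower from compound 3 to compound 4 (beyond the scatter), and this step matches the one seen on the core of compound 1: the same change on two cores in this assay, a number 14.6 percentage points lower (beyond the scatter) from compound 1 to compound 2 and a number 19.7 percentage points lower (beyond the scatter) from compound 3 to compound 4, 5.1 percentage points apart, within the scatter of two such steps. Likewise, 1H-imidazol-1-yl in place of 1H-1,2,4-triazol-1-yl gave a number 0.7 percentage points lower from compound 2 to compound 4 (within the scatter), so this exchange again separates nothing, whichever group sits on the amine nitrogen in the ring: the same change on two cores in this assay, a number 4.4 percentage points higher (within the scatter) from compound 1 to compound 3 and a number 0.7 percentage points lower (within the scatter) from compound 2 to compound 4, 5.1 percentage points apart, within the scatter of two such steps. Across these compounds, the loss of inhibition with methylsulfonyl therefore carries from one core to the other, but this rests on only two cores that the assay does not tell apart, at a single concentration, and it shows neither how the change would behave on a more different core nor what lies behind the step.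

The compounds shown leave open which part of the (4-(trifluoromethyl)phenyl)carbonyl group matters, since a plain benzoyl or an acetyl group on the same nitrogen would separate the trifluoromethyl, the aromatic ring and the carbonyl. They also leave open whether the step would survive if the 4-(dimethylamino)phenyl group gave way to, for example, a methoxyphenyl or a pyridine.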